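The source may hold more compounds than are shown below. What is called first, only, known or untested is meant among the compounds shown, and "the series" means these compounds.

Three compounds share one core and differ only in the aryl group attached to the carbonyl carbon. In a functional assay on Malme-3M cells (Homo sapiens) for inhibition, read by sulforhodamine B assay, with a stated time of 48 h (a lower number here means a stronger inhibitor of growth, a higher number a weaker inhibitor of growth), compound 1 `COc1cc(-c2cc(/C=C/C(=O)c3ccc(N)cc3)[nH]n2)cc(OC)c1OC` gives 2050 nM, compound 2 `COc1cc(-c2cc(/C=C/C(=O)c3ccc(Cl)c(Cl)c3)[nH]n2)cc(OC)c1OC` gives 29200 nM, and compound 3 `COc1ccc(C(=O)/C=C/c2cc(-c3cc(OC)c(OC)c(OC)c3)n[nH]2)cc1OC` gives 1990 nM. Compound 3 holds the lowest of the three numbers, though compound 1 sits within the scatter of it, while the steps of a 14-fold higher number from compound 1 to compound 2 (1.15 log units; beyond the scatter) and a 15-fold lower number from compound 2 to compound 3 (1.17 log units; beyond the scatter) were both large. Compound 4 `COc1cc(-c2cc(/C=C/C(=O)c3ccc(F)c(F)c3)[nH]n2)cc(OC)c1OC` differs from compound 3 by 3,4-difluorophenyl in place of 3,4-dimethoxyphenyl on a carbonyl carbon. The step of a 15-fold lower number from compound 2 to compound 3 (1.17 log units; beyond the scatter) bears on this most closely, since 3,4-dichlorophenyl is the nearest relative of 3,4-difluorophenyl among the measured groups. Compound 4 is therefore expected to give a higher number in this assay, an estimated step of a 6.0-fold higher number from compound 3 to compound 4 (0.78 log units; beyond the scatter), with an expected 12000 nM and a range from 4000 nM to 40000 nM.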

Compound 4, concentration for 50% growth inhibition: 2960 nM
For compound 4 the middle estimate is 4.1-fold (0.61 log units) above the measured one; measured number below the stated range.
By their numbers in this assay, from the lowest: compounds 3, 1 and 4 (each within the scatter of the next); then compound 2.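

In this assay, the step of a 9.9-fold lower number from compound 2 to compound 4 (0.99 log units; beyond the scatter) shows that the high number of compound 2 is not shared by every dihalogenated phenyl group on this carbonyl carbon. The steps of a 1.5-fold higher number from compound 3 to compound 4 (0.17 log units; within the scatter) and a 1.4-fold higher number from compound 1 to compound 4 (0.16 log units; within the scatter) place 3,4-difluorophenyl level with 3,4-dimethoxyphenyl and 4-aminophenyl, although it shares neither group's oxygen nor nitrogen atoms. No measurement offered here accounts for the gap between the fluorine and chlorine compounds. On these data alone, whether 3,4-dibromophenyl would follow compound 2 or compound 4 remains open, as does the effect of a single fluorine in 4-fluorophenyl.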